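A Fluoro Step Repeated on a Second Core

A few compounds are considered here, and "the series" means these few. Any claim that something is new, unique, unknown or untested is made for them only; others in the source may bear on it.

The measured compounds and their values in an ADME assay (liver) for metabolic stability, with Liver microsome (Rattus norvegicus) as the target, using microsomes; on this read-out lower numbers stand for slow clearance and higher numbers for fast clearance:
compound 1, `c1ccc(CNc2nnc(-c3c[nH]c4ncccc34)o2)cc1`: 40 mL.min-1.g-1
compound 2, `Fc1ccc(CNc2nnc(-c3c[nH]c4ncccc34)o2)cc1`: 58 mL.min-1.g-1
compound 3, `Fc1ncccc1[C@H](Nc1nnc(-c2c[nH]c3ncccc23)o1)C1CC1`: 80 mL.min-1.g-1

Compound 1 and compound 2 share a core and differ in one place, (fluoro in place of hydrogen on an aromatic carbon). In this assay this gave a 1.5-fold higher number from compound 1 to compound 2 (0.16 log units; within the scatter), so the two numbers are not told apart by the measurement.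

Compound 3 stands on a different core; the difference between its core and that of compound 1 is not broken down here. Among the three measured compounds, compound 3 has the highest number, but its gaps to compound 2 and to compound 1 are both within the usual scatter, so no ordering is claimed.

Compound 4, `Fc1ccc2c(-c3nnc(N[C@@H](c4cccnc4F)C4CC4)o3)c[nH]c2n1`, is not yet measured. It differs from compound 3 by fluoro in place of hydrogen on an aromatic carbon. Among the compounds with values here, this is the same kind of change as the one from compound 1 to compound 2, but not the same: there the fluoro entered a six-membered aromatic ring of carbon only, para to a large group, while here it enters a six-membered aromatic ring with one nitrogen, part of a fused system of two rings, next to the ring nitrogen. Within the data shown here, the only precedent in this set is the step from compound 1 to compound 2, which stayed within the scatter. On that basis, compound 4 is expected to show a 1.3-fold higher number from compound 3 to compound 4 (0.10 log units; within the scatter) in this assay, a step of the same modest size as the earlier one. The estimate for compound 4 in this assay is 100 mL.min-1.g-1, with a range from 50 mL.min-1.g-1 to 200 mL.min-1.g-1.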

Compound 4, intrinsic clearance in microsomes: 413 mL.min-1.g-1
Compound 4: the middle estimate sits 4.1-fold (0.62 log units) below what was measured; the measured number lies above the stated range.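

In this assay, fluoro in place of hydrogen on an aromatic carbon gave a 5.2-fold higher number from compound 3 to compound 4 (0.71 log units; beyond the scatter), a step that lies beyond the scatter, whereas the earlier step did not. The change therefore did not carry over from one core to the other at the same size, and the two steps differ: the same change on two cores in this assay, a 1.5-fold higher number (0.16 log units; within the scatter) from compound 1 to compound 2 and a 5.2-fold higher number (0.71 log units; beyond the scatter) from compound 3 to compound 4, 3.6-fold (0.55 log units) apart, beyond the scatter of two such steps. This does not show why they differ: the fluoro enters a different ring in each pair and the two cores also differ in other places, so two steps cannot separate the role of the core from that of the place of substitution, and they predict nothing for a further core.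

The compounds shown leave open whether another small group on the same aromatic carbon, such as chloro, methyl or a nitrile, would give a step of similar size to that of fluoro. Also open, from the compounds shown here alone, is how large the step would be if fluoro entered the same place, next to the ring nitrogen, on compound 1 or compound 2, which would show whether the large step belongs to that place alone or needs the rest of compound 3.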